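The source may hold more compounds than are shown below. What is called first, only, known or untested is meant among the compounds shown, and "the series" means these compounds.

Working notes on the series. Compound 1 `COc1cc2c(Oc3ccc(NC(=O)c4nnn(-c5ccc(F)cc5)c4C(F)(F)F)cc3F)ccnc2cc1OCCCN1CCCC1` is read in a functional assay on U-87MG ATCC cells (Homo sapiens) for cytotoxicity, read by MTT assay, with a stated time of 72 h (a lower number here means a stronger inhibitor, a higher number a weaker inhibitor), and gives 850 nM. Among the compounds with values here, the only other number in the set is that of compound 3 `COc1cc2c(Oc3ccc(NC(=O)c4nnn(-c5ccccc5C(F)(F)F)c4C(F)(F)F)cc3F)ccnc2cc1OCCCN1CCCC1`, which in this assay gives 1180 nM; the step of a 1.4-fold higher number from compound 1 to compound 3 (0.14 log units; within the scatter) is within the scatter, so the two compounds sit level. Compound 2 `COc1cc2c(Oc3ccc(NC(=O)c4nnn(-c5ccc(C)cc5)c4C(F)(F)F)cc3F)ccnc2cc1OCCCN1CCCC1` has no result, "not determined" (no result reported), and so adds nothing to the comparison.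

Compound 4 `COc1cc2c(Oc3ccc(NC(=O)c4nnn(-c5ccc(F)cc5)c4C(F)(F)F)cc3F)ccnc2cc1OCCCN1CCCCC1` differs from compound 1 in one place: piperidin-1-yl in place of pyrrolidin-1-yl on a saturated chain carbon, three bonds along the chain from an oxygen on an aromatic ring. Within the data shown here, no measured step in this set touches the pyrrolidin-1-yl end of the chain; the single step measured, from compound 1 to compound 3, concerns a change on the aromatic nitrogen at the other end of the molecule and was itself within the scatter. There is thus no measured basis for a shift in either direction, and compound 4 is expected to stay near compound 1, with no change at the digits printed from compound 1 to compound 4 (within the scatter) as the estimated step. For compound 4 the expected value in this assay is 850 nM, with a range of 400 nM to 1800 nM.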

Compound 4, half-maximal inhibitory concentration: 1100 nM
The estimate for compound 4 lay 1.3-fold (0.11 log units) below the measured number; measured number inside the range.
By their numbers in this assay, from the lowest: compounds 1, 4 and 3 (each within the scatter of the next).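

In this assay, within the data shown here, the exchange of pyrrolidin-1-yl for piperidin-1-yl gives a 1.3-fold higher number from compound 1 to compound 4 (0.11 log units; within the scatter) and is the first measured step at this end of the chain. At this position, on a saturated chain carbon, three bonds along the chain from an oxygen on an aromatic ring, the five-membered and six-membered non-aromatic rings therefore sit level, although this rests on a single pair of compounds. No supporting measurement bears on this result.

From the compounds shown here alone, whether morpholin-4-yl, an open-chain dimethylamino group or a longer chain in place of the 3-(piperidin-1-yl)propyl group would move the number beyond the scatter remains open. Also open, going by these compounds, is whether piperidin-1-yl would read the same alongside the 2-(trifluoromethyl)phenyl group of compound 3.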